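Halogenated aryl ethers on the shared core

The source may report more compounds than this note shows. Statements on the series, on what has been measured and on what is new or still open speak of the compounds shown alone.

Two members of the series carry reported numbers. Compound 1 `NC1=NC2(CCOCC2)N(OCCCOc2cccc(Cl)c2)C(N)=N1` in a functional assay on MDA-MB-231 cells (Homo sapiens) for antiproliferative activity, read by MTT assay, with a stated time of 72 h (a lower number here means a stronger inhibitor, a higher number a weaker inhibitor), gives 1020 nM, and compound 2 `NC1=NC2(CCOCC2)N(OCCCOc2ccc(Cl)c(Cl)c2)C(N)=N1` in this assay gives 590 nM. Going by the values given here, the single measured step, a 1.7-fold lower number from compound 1 to compound 2 (0.24 log units; within the scatter), does not separate the two compounds beyond the scatter, so the numbers of compound 1 and compound 2 are read as equivalent.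

Compound 3 `NC1=NC2(CCOCC2)N(OCCCOc2ccc(Cl)cc2Cl)C(N)=N1` stands without a number: in this assay compound 3 is recorded as "not determined" (no result reported), so no comparison to it can be drawn.

Compound 4 `NC1=NC2(CCOCC2)N(OCCCOc2cccc(Br)c2)C(N)=N1` differs from compound 3 in that (3-bromophenyl in place of 2,4-dichlorophenyl on an oxygen on a saturated carbon). Among the compounds with values here, no measured step covers this change, and compound 3 offers no anchor. The nearest measured reference is compound 1, whose structure differs from compound 4 only in the halogen on the aryl ring, and the step from compound 1 to compound 2 shows that halogen changes on this ring stayed within the scatter. Compound 4 is therefore expected to sit close to compound 1 in this assay, estimated at 1000 nM with a range of 400 nM to 2500 nM.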

Compound 4, half-maximal inhibitory concentration: 400 nM
Estimate against measurement, compound 4: 2.5-fold (0.40 log units) above, within the range that was stated.
By their numbers in this assay, from the lowest: compounds 4, 2 and 1 (each within the scatter of the next, the first and the last beyond it).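

Bromo in place of chloro on an aromatic carbon gives a 2.6-fold lower number from compound 1 to compound 4 (0.41 log units; beyond the scatter) in this assay and is the first halogen change on this aryl ring to clear the scatter. Going by these compounds alone, the change to 3-bromophenyl from 3,4-dichlorophenyl gives a 1.5-fold lower number from compound 2 to compound 4 (0.17 log units; within the scatter) so that the single bromo group and the two chloro groups of compound 2 read as equivalent on this ring. No evidence at hand bears on the reason for the difference seen on going from chloro to bromo.

Still open, as far as these compounds go, is how an iodo or trifluoromethyl group, or a plain phenyl, would compare with 3-bromophenyl on this oxygen-linked chain. From the compounds shown here alone, the 2,4-dichlorophenyl group of compound 3 has no value to place it, and the effect of a longer chain or an amine on the ring remains unknown.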